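This account rests on a few compounds, and the source may have more. Where it says the series, first, only, none or still open, it means among the compounds named here.

Measured in a functional assay on MCF7 cells (Homo sapiens) for cytotoxicity, read by MTT assay, with a stated time of 48 h (on this read-out higher numbers stand for weaker inhibition and lower numbers for stronger inhibition), as follows
Compound 1 `COc1ccc(Nc2nc(-c3cccc(F)c3)nc3ccc(F)cc23)cc1` gives 48400 nM as a number
Compound 2 `Fc1cccc(-c2nc(Nc3ccccc3F)c3cc(F)ccc3n2)c1` gives > 50000 nM as a limit
Compound 3 `Cc1cccc(Nc2nc(-c3cccc(F)c3)nc3ccc(F)cc23)c1` gives > 50000 nM as a limit

In this assay compound 3 reads > 50000 nM and this is a limit of the assay, not a number. Compound 2 sits at the same limit, so the series is framed by the limit of > 50000 nM in this assay, at which 2 of the 3 values shown sit, and only compound 1 gives a number.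

Compound 4 `Cc1ccccc1Nc1nc(-c2cccc(F)c2)nc2ccc(F)cc12` has the same atoms as compound 3, joined differently: 2-methylphenyl in place of 3-methylphenyl on a nitrogen on an aromatic ring with 2-methylphenyl in place of 3-methylphenyl on a nitrogen on an aromatic ring. Going by the values given here, no measured step makes this exact change, but three steps alter the same group on that nitrogen. Two of them are floors only, namely an at least 1.0-fold higher number from compound 1 to compound 2 (0.01 log units; that floor lies within the scatter) and an at least 1.0-fold higher number from compound 1 to compound 3 (0.01 log units; that floor lies within the scatter) and neither goes beyond the scatter. The third is a step that the two limits leave unreadable from compound 2 to compound 3 and it gives no size at all. Given an at least 1.0-fold higher number from compound 1 to compound 3 (0.01 log units; that floor lies within the scatter) and nothing larger among the readable steps, no step beyond the scatter is expected in this assay for this change. The expected step is a number no higher from compound 3 to compound 4 (the limit leaves the size open) and it remains an estimate set against a limit. For compound 4 the estimated value is 50000 nM with an expected range from 25000 nM to 100000 nM and it may well prove to be only a limit.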

Compound 4, half-maximal inhibitory concentration: > 50000 nM
Compound 4 ended at the assay's limit (the forecaster's own chance of this, stated with the estimate: 70%); the middle value lies on the limit itself.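

In this assay the 2-methylphenyl group on the nitrogen gives no more of a number than the 3-methylphenyl group did, so moving the methyl between these two named forms brings no readable change: compound 4 reads > 50000 nM, and this is a limit of the assay, not a number. Going by these compounds alone, measured against the only number, the change reads as an at least 1.0-fold higher number from compound 1 to compound 4 (0.01 log units; that floor lies within the scatter), so even this comparison shows no step beyond the scatter. The steps from compound 3 and from compound 2 to compound 4 cannot be read, and the swap of fluoro for methyl therefore has no size either, leaving 4-methoxyphenyl in compound 1 as the only group on that nitrogen with a number, and the series is now bounded more firmly than before: the limit of > 50000 nM in this assay, at which 3 of the 4 values shown sit.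

On these data alone, how far compounds 2, 3 and 4 lie beyond that limit stays unknown, so no order among them can be given. As far as these compounds go, whether a carboxylic acid, an amine or a longer chain on the phenyl ring would give a clear number in this assay also stays open.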